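Cytotoxicity notes: removing the methoxy from compound 3

The source may report more compounds than this note shows. Statements on the series, on what has been measured and on what is new or still open speak of the compounds shown alone.

Measured compounds in a functional assay on HeLa cells (Homo sapiens) for cytotoxicity, read by MTT assay, with a stated time of 24 h; on this read-out higher numbers stand for weaker inhibition and lower numbers for stronger inhibition:
- compound 1, `[N-]=[N+]=Nc1cc2ccc(O)cc2oc1=O`: 41600 nM
- compound 2, `[N-]=[N+]=Nc1cc2cc(Br)ccc2oc1=O`: 28300 nM
- compound 3, `COc1cccc2cc(-n3nnc4c3-c3ccccc3N(C(=O)CCN)Cc3ccccc3-4)c(=O)oc12`: 26200 nM

Of the compounds shown here, three have been measured. Compound 1 `[N-]=[N+]=Nc1cc2ccc(O)cc2oc1=O` and compound 2 `[N-]=[N+]=Nc1cc2cc(Br)ccc2oc1=O` carry small substituents on the shared core; compound 3 `COc1cccc2cc(-n3nnc4c3-c3ccccc3N(C(=O)CCN)Cc3ccccc3-4)c(=O)oc12` carries a much larger fused tricyclic attachment bearing a side chain with a primary amine. In this assay compound 3 gives 26200 nM. Of the three numbers this is the smallest, yet the gap to compound 2 and the gap to compound 1 both lie within the scatter, so the three are not told apart by these data.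

Compound 4 `NCCC(=O)N1Cc2ccccc2-c2nnn(-c3cc4ccccc4oc3=O)c2-c2ccccc21` has not been measured. It differs from compound 3 in one place: hydrogen in place of methoxy on an aromatic carbon. Among the measured compounds shown here, no measured pair shows the effect of this change, so there is nothing to set a direction or size. Given that the three measured numbers sit within the scatter of one another, the expected step of a 1.1-fold higher number from compound 3 to compound 4 (0.03 log units; within the scatter) is none beyond the scatter. Compound 4 is therefore estimated at 28000 nM, with a range from 12000 nM to 70000 nM.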

Compound 4, half-maximal inhibitory concentration: 19800 nM
Compound 4: the middle estimate sits 1.4-fold (0.15 log units) above what was measured; measured number inside the range.
By their numbers in this assay, from the lowest: compounds 4, 3, 2 and 1 (each within the scatter of the next, the first and the last beyond it).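

In this assay, among the compounds shown here, hydrogen in place of methoxy gives a 1.3-fold lower number from compound 3 to compound 4 (0.12 log units; within the scatter) and is the only direct reading of this position, an aromatic carbon of a six-membered aromatic ring of carbon only. Methoxy at this place is therefore not required to keep the number at the level of compound 3, and the data do not tell compound 3 and compound 4 apart. Nothing at hand offers a cause for this step.

From the compounds shown here alone, it remains open whether a carboxylic acid or a longer alkoxy chain on this carbon would move the number beyond the scatter. Going by these compounds, it is also open whether the same exchange of methoxy for hydrogen would give a similar step with another side chain in place of the one carrying the primary amine.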